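Trifluoromethyl to Methoxymethyl on the Butyl Chain

The compounds below may be only part of what the source reports. "The series", "measured", "known", "first", "only" and "open" are said of these compounds alone.

In an assay on HEK293 cells for inhibition of solute carrier family 12 member 2 (Homo sapiens), read by fluorescence, with a stated time of 30 min, tested at 100 uM (a lower number here means a weaker effect, a higher number a stronger effect of the compound at the concentration tested), the three measured compounds stand as follows:
compound 1 `CC(C)(C)CCNc1ccc([N+](=O)[O-])cc1S(N)(=O)=O` gives 14.5%
compound 2 `CCCCNc1ccc(C(=O)O)cc1S(=O)(=O)N(C)C` gives 15.6%
compound 3 `CN(C)S(=O)(=O)c1cc(C(=O)O)ccc1NCCCC(F)(F)F` gives 1.9%

Compound 3 stands lowest of the three in this assay, beyond the scatter from both compound 1 and compound 2. Compound 4 `COCCCCNc1ccc(C(=O)O)cc1S(=O)(=O)N(C)C` differs from compound 3 by methoxymethyl in place of trifluoromethyl on a saturated chain carbon, three bonds along the chain from a nitrogen on an aromatic ring. Among the measured compounds shown here, the one measured step that bears on this place is a number 13.7 percentage points lower from compound 2 to compound 3 (beyond the scatter), where the trifluoromethyl group went with the lowest number. Since compound 4 removes that group again, a step back upward, of roughly the size seen there, is expected: a number 10.1 percentage points higher from compound 3 to compound 4 (beyond the scatter). Compound 4 is therefore estimated at 12% in this assay, with a range from 0% to 26%.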

Compound 4, a percentage reported as inhibition, at one concentration (the size of the read-out at that concentration, not a potency): 5.2%
The estimate for compound 4 lay 6.8 percentage points above the measured number, within the range that was stated.
By their numbers in this assay, from the lowest: compounds 3, 4, 1 and 2 (each within the scatter of the next, the first and the last beyond it).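

In this assay the change from trifluoromethyl to methoxymethyl gave a number 3.3 percentage points higher from compound 3 to compound 4 (within the scatter) and so did not restore the number of the plain butyl chain. Methoxy on the chain end also gave a number 10.4 percentage points lower from compound 2 to compound 4 (beyond the scatter) as a step of its own. At this place, then, two different end groups now go with a lower number than the unsubstituted butyl chain. As far as these compounds go, whether a hydroxyl group, an amine or a longer chain at this place would keep the number of the butyl chain stays open. No measurement shown gives an explanation for this result.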